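Nitro in Place of Methyl on the Aromatic Ring

The source may hold more compounds than are shown below. What is called first, only, known or untested is meant among the compounds shown, and "the series" means these compounds.

Compound 1 `Cc1cc(C)cc(CC(C(=O)O)[C@H](N)C(=O)O)c1`: 36%
Compound 2 `Cc1cccc(CC(C(=O)O)[C@H](N)C(=O)O)c1`: 33%
Compound 3 `N[C@H](C(=O)O)C(Cc1c(Cl)cccc1Cl)C(=O)O`: 86%

Of the compounds shown here, three sharing one core have been measured in an in vitro assay on cells for inhibition of excitatory amino acid transporter 3 (Homo sapiens), tested at 100 uM; a higher number here means more inhibition at the concentration tested (going by the name of the read-out), a lower number less inhibition. Compound 2 gives the lowest of the three numbers. Its nearest neighbour is compound 1, and the step of a number 3 percentage points lower from compound 1 to compound 2 (within the scatter) lies within the scatter, so the two cannot be told apart. Going by the values given here, compound 3 stands far higher, beyond the scatter, but no single change separates it from compound 2, so its value shows only that a much higher number is possible on this core.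

Compound 4 `N[C@H](C(=O)O)C(Cc1cccc([N+](=O)[O-])c1)C(=O)O` has not yet been measured. It differs from compound 2 in one place: nitro in place of methyl on an aromatic carbon. Among the compounds with values here, the only measured step at an aromatic carbon, a number 3 percentage points lower from compound 1 to compound 2 (within the scatter), put hydrogen in place of methyl and stayed within the scatter. Within the data shown here, no measured step introduces a nitro, so nothing points to a change beyond the scatter in either direction, and the expected step of a number 7 percentage points higher from compound 2 to compound 4 (within the scatter) is therefore small. Compound 4 is accordingly estimated at 40%. The expected range for compound 4 is estimated to run from 20% to 65%. This range is wide. No comparable change has been measured.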

Compound 4, a percentage reported as inhibition, at one concentration (the size of the read-out at that concentration, not a potency): 29%
Compound 4: the middle estimate sits 11 percentage points above what was measured; the range from low to high includes it.
By their numbers in this assay, from the lowest: compounds 4, 2 and 1 (each within the scatter of the next); then compound 3.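

In this assay, replacing a methyl with a nitro on this aromatic carbon, meta to a large group, gives a number 4 percentage points lower from compound 2 to compound 4 (within the scatter), so compound 2 and compound 4 cannot be told apart. Going by these compounds alone, this is the first measured change on the ring that puts a new group in place of a methyl rather than just removing one: 1 heavy atom leaves and 3 heavy atoms enter, along with 2 hydrogen-bond acceptors, yet the read-out stays within the scatter, as it did for the step of a number 3 percentage points lower from compound 1 to compound 2 (within the scatter). Nothing measured here explains why this larger change leaves the number so close to that of compound 2.

Going by these compounds, whether an amine or a carboxylic acid on this same aromatic carbon would also stay within the scatter of compound 2 remains open. Compound 3, at 86%, shows that a far higher number is possible on the shared core, but it differs from compound 2 in more than one place, so the compounds shown do not tell which of those differences goes with that number.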